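From azido to hydroxy on the carbonyl side chain

The compounds below may be only part of what the source reports. "The series", "measured", "known", "first", "only" and "open" are said of these compounds alone.

compound 1 `COC(=O)N1N=C(c2ccc(N(C)C)cc2)OC1c1cc(OC)c(OC)c(OC)c1`: 40 uM
compound 2 `COc1cc(C2OC(c3ccc(N(C)C)cc3)=NN2C(=O)CN=[N+]=[N-])cc(OC)c1OC`: 0.15 uM

Going by the values given here, in a functional assay on HCT-15 cells (Homo sapiens) (a higher number here means that more compound is needed for the effect, a lower number that less compound is needed), compound 2 gives 0.15 uM, the lower of the two numbers measured so far, well apart from compound 1 at 40 uM. Compound 3 `COc1cc(C2OC(c3ccc(N(C)C)cc3)=NN2C(=O)CO)cc(OC)c1OC` keeps the core of compound 2 and alters one group: hydroxy in place of azido on a saturated chain carbon bound to a carbonyl carbon. Put simply, it carries hydroxy in place of azido on a saturated chain carbon bound to a carbonyl carbon.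

Among the compounds with values here, only one measured step bears on this change, and only indirectly. That step, a 270-fold lower number from compound 1 to compound 2 (2.43 log units; beyond the scatter), is large and shows that the group on the carbonyl carbon can move the number strongly in this assay. Within the data shown here, no measured pair exchanges the azido itself, so the size of the new step remains open. With compound 2 at the low end of the numbers, a moderate move upward seems more likely than a further drop, and a smaller one than the step from the methoxy compound. The expected change is an 8.0-fold higher number from compound 2 to compound 3 (0.90 log units; beyond the scatter). For compound 3 the estimated value is 1.2 uM, with an expected range of 0.2 uM to 8 uM.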

Compound 3, concentration for half-maximal effect: 0.026 uM
Compound 3: the middle estimate sits 46-fold (1.66 log units) above what was measured; measured number outside the range, below it.
By their numbers in this assay, from the lowest: compound 3; then compound 2; then compound 1.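

In this assay, the exchange of azido for hydroxy on a saturated chain carbon bound to a carbonyl carbon gives a 5.8-fold lower number from compound 2 to compound 3 (0.76 log units; beyond the scatter), so the low number at this position does not depend on azido and the number can still fall from there. Against the methoxy compound, hydroxymethyl on the carbonyl carbon gives a 1500-fold lower number from compound 1 to compound 3 (3.19 log units; beyond the scatter), which goes further than a 270-fold lower number from compound 1 to compound 2 (2.43 log units; beyond the scatter) with azidomethyl. Among these compounds, then, the large drop from compound 1 holds for both chain groups, while the group on the chain carbon still sets how far the number falls, with hydroxy, which brings a hydrogen-bond donor that azido lacks, giving the lowest number of the three.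

Still open, from the compounds shown here alone, is whether an amine or a carboxylic acid on the same chain carbon, a methyl ether of the hydroxy, or a longer chain carrying the hydroxy would keep the number this low or move it further. No evidence at hand explains why hydroxy gives a lower number than azido.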